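From fluoro to chloro: compound 3 to compound 4

The source may report more compounds than this note shows. Statements on the series, on what has been measured and on what is new or still open speak of the compounds shown alone.

Values from a functional assay on HepG2 cells (Homo sapiens) for antiproliferative activity, read by MTT assay, with a stated time of 24 h (a higher number here means a weaker inhibitor, a lower number a stronger inhibitor), are these
- compound 1 `Cc1ccc(-c2nn(-c3ccccc3)cc2-c2nc3ccccc3n2S(=O)(=O)c2ccc(Cl)cc2)cc1` gives 5520 nM
- compound 2 `O=S(=O)(c1ccccc1)n1c(-c2cn(-c3ccccc3)nc2-c2ccc(F)cc2)nc2ccccc21` gives 720 nM
- compound 3 `O=S(=O)(c1ccc(F)cc1)n1c(-c2cn(-c3ccccc3)nc2-c2ccc(F)cc2)nc2ccccc21` gives 3520 nM

Compound 3 and compound 1 lie within the scatter of each other, so no order between them can be read. Compound 4 `O=S(=O)(c1ccc(Cl)cc1)n1c(-c2cn(-c3ccccc3)nc2-c2ccc(F)cc2)nc2ccccc21` departs from compound 3 in one place: chloro in place of fluoro on an aromatic carbon, para to a large group.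

For the measured compounds named here, one measured step bears on this place: a 4.9-fold higher number from compound 2 to compound 3 (0.69 log units; beyond the scatter), on fluoro replacing hydrogen. Going by the values given here, it shows that a change here can move the number beyond the scatter, but it starts from hydrogen, and no measured step goes from fluoro to chloro. Compound 4 carries the same (4-chlorophenyl)sulfonyl group as compound 1 but differs from it elsewhere, and the value of compound 1, 5520 nM, stays within the scatter of compound 3.

No step beyond the scatter is therefore expected in this assay, and the estimated step is a 1.1-fold higher number from compound 3 to compound 4 (0.06 log units; within the scatter). For compound 4 the estimated value is 4000 nM, with an expected range from 1500 nM to 10000 nM.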

Compound 4, half-maximal inhibitory concentration: 4230 nM
Beside the measured number, compound 4's estimate is 1.1-fold (0.02 log units) below it; the measured number falls inside the stated range.
By their numbers in this assay, from the lowest: compound 2; then compounds 3, 4 and 1 (each within the scatter of the next).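

With the (4-fluorophenyl)sulfonyl group changed to (4-chlorophenyl)sulfonyl in this assay, the result is a 1.2-fold higher number from compound 3 to compound 4 (0.08 log units; within the scatter), so the two halogens cannot be told apart at this position. Chloro in place of hydrogen gives a 5.9-fold higher number from compound 2 to compound 4 (0.77 log units; beyond the scatter), which is beyond the scatter, so the shift first seen with fluoro in a 4.9-fold higher number from compound 2 to compound 3 (0.69 log units; beyond the scatter) is now seen with a second halogen, and compound 2, which carries hydrogen here, stands apart from both compound 3 and compound 4. At a second place, with the (4-chlorophenyl)sulfonyl group held constant, fluoro in place of methyl on an aromatic carbon gives a 1.3-fold lower number from compound 1 to compound 4 (0.12 log units; within the scatter), a step within the scatter, and no measurement shown here explains any of these results.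

Going by these compounds, it remains open whether the link between a substituent at this position and a higher number extends beyond the two halogens, for example to methyl, methoxy, trifluoromethyl, an amine or a carboxylic acid. On these data alone, it also remains open whether hydrogen at this position would keep its lower number when methyl replaces fluoro at the second place.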